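The compounds below may be only part of what the source reports. "The series", "measured", "known", "first", "only" and "open" are said of these compounds alone.

Measured so far in an assay on CHO cells for displacement of a labelled ligand from muscarinic acetylcholine receptor M5 (Homo sapiens), read by scintillation counting, with a stated time of 2 h; a lower number here means a stronger inhibitor, a higher number a weaker inhibitor:

- compound 1 `Cc1ccc(CCCOC(=O)N(c2ccccc2)C2CN3CCC2CC3)cc1F`: 130 nM
- compound 2 `COc1ccc(COC(=O)N(c2ccccc2)C2CN3CCC2CC3)cc1OC`: 550 nM
- compound 3 `COc1ccc(CCOC(=O)N(c2ccccc2)C2CN3CCC2CC3)cc1OC`: 3490 nM

Compound 2 sits second highest of the three numbers in this assay. Its nearest neighbour is compound 1, whose number is lower beyond the scatter; its furthest is compound 3, whose number is higher, again beyond the scatter. Among the measured compounds shown here, the one step that can be set out within the measured set is a 27-fold higher number from compound 1 to compound 3 (1.43 log units; beyond the scatter), which alters the chain and the aryl substitution at once and so says little about a single aryl substituent.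

Compound 4 `COc1ccc(COC(=O)N(c2ccccc2)C2CN3CCC2CC3)cc1` differs from compound 2 by hydrogen in place of methoxy on an aromatic carbon. For the measured compounds named here, no measured step removes a methoxy alone, so there is no direct precedent. Going by the values given here, the spread between compound 2 and compound 3 shows that changes around the aryl group can move this assay, but with no matched pair the expected shift is small and of uncertain direction. The estimate for compound 4 is therefore 500 nM (range 180 nM to 1500 nM), a step of a 1.1-fold lower number from compound 2 to compound 4 (0.04 log units; within the scatter) expected to lie within the scatter.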

Compound 4, inhibition constant: 470 nM
Compound 4: the middle estimate sits 1.1-fold (0.03 log units) above what was measured; the range from low to high includes it.
By their numbers in this assay, from the lowest: compound 1; then compounds 4 and 2 (each within the scatter of the next); then compound 3.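

In this assay, among the compounds shown here, hydrogen in place of methoxy on an aromatic carbon, ortho to a methoxy group and meta to a large group, gives a 1.2-fold lower number from compound 2 to compound 4 (0.07 log units; within the scatter), the first step that alters this position alone. Compound 2 and compound 4 therefore read alike, so this methoxy can be removed without a shift beyond the scatter, whereas the earlier step changed the chain and the aryl substitution together and could not show this. No available evidence bears on why this change leaves the number within the scatter.

Still open, going by these compounds, is whether a hydroxy group, an ethoxy group or a fluorine at this position would also leave the number within the scatter, and whether the remaining methoxy can be removed as well. Also open, on these data alone, is whether the same change would read alike on the chain of compound 3.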